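Shortening the Amine Chain from Butyl to Propyl

The compounds below may be only part of what the source reports. "The series", "measured", "known", "first", "only" and "open" are said of these compounds alone.

Four compounds share one core and differ only in the amine that hangs from it. Compound 1 `COc1ccccc1-c1cc(C2CCNC2)ccc1Cl` holds its nitrogen within a saturated ring, and in a functional assay on HEK293 cells for agonist activity at 5-hydroxytryptamine receptor 7 (Homo sapiens), read by a luciferase reporter and beta-arrestin recruitment, with a stated time of 22 h (a higher number here means that more compound is needed for the effect, a lower number that less compound is needed), compound 1 gives 75.9 nM; 75 nM (2 entries), the two entries agreeing closely (the several entries of compound 1 in this assay, 75.9 nM; 75 nM (2 entries)). Compound 2 `COc1ccccc1-c1cc(CN(C)C)ccc1Cl` carries a dimethylamine, and in this assay compound 2 gives 479 nM; 480 nM (2 entries), again with agreeing entries (the several entries of compound 2 in this assay, 479 nM; 480 nM (2 entries)). Compound 3 `CCCCNCc1ccc(Cl)c(-c2ccccc2OC)c1` places a butyl group on a secondary amine; in this assay compound 3 is reported as "not active" (no number reported), with no single number given for it, and two further entries likewise lack a number. Compound 3 therefore stands apart from compound 1 and compound 2, each of which has a measured number.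

Compound 4 `CCCNCc1ccc(Cl)c(-c2ccccc2OC)c1` is to be measured in this assay. It differs from compound 3 by hydrogen in place of methyl on a saturated chain carbon, three bonds along the chain from an amine nitrogen; read one bond further out, this is butyl becoming propyl. For the measured compounds named here, no measured pair shows the effect of such a shortening, so the expected step is small and of uncertain direction; a shift toward less compound being needed is plausible since compound 2 gives 479 nM; 480 nM (2 entries), yet the result may also stay within the scatter or again leave compound 4 without a number. Compound 4 is expected to give about 3000 nM in this assay, within a range from 700 nM to 20000 nM, with a real chance that only an inactive result is reported.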

Compound 4, half-maximal effective concentration: "not active" (no number reported)
Compound 4: no number reported; the estimate stays without a comparison.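

In this assay, for the compounds shown here, compound 3 and compound 4 are both reported as not active, with no number for either, so no step from butyl to propyl can be read between them, and nothing in the available evidence bears on this result. On these data alone, whether shortening this chain changes the measured agonist effect at all remains open.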